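Moving a hydroxyl group on a shared core

A few compounds are considered here, and "the series" means these few. Any claim that something is new, unique, unknown or untested is made for them only; others in the source may bear on it.

Of the compounds shown here, two built on the same core have been tested in a functional assay on HCT-15 cells (Homo sapiens) for inhibition; on this read-out lower numbers stand for stronger inhibition and higher numbers for weaker inhibition. Compound 1, `Oc1cccc(-c2cc(-c3ccc(C(F)(F)F)cc3)cc(-c3ccccc3O)n2)c1`, carries a trifluoromethyl-bearing ring together with a 3-hydroxyphenyl and a 2-hydroxyphenyl group. In this assay compound 1 gives > 50000 nM, which is a limit of the assay rather than a measured number. Compound 2, `Oc1ccccc1-c1cc(-c2ccc(OC(F)(F)F)cc2)cc(-c2ccccc2O)n1`, has a trifluoromethoxy group instead and carries two 2-hydroxyphenyl groups. In this assay compound 2 gives > 50000 nM, again a limit and not a number. So compound 2 stands at the same limit as the only other value available, both sitting at the limit of > 50000 nM in this assay, at which 2 of the 2 values shown sit. Compound 3, `Oc1cccc(-c2cc(-c3ccc(OC(F)(F)F)cc3)cc(-c3ccccc3O)n2)c1`, is built from compound 2 by a change in which the atoms stay the same but are joined differently: 3-hydroxyphenyl in place of 2-hydroxyphenyl on an aromatic carbon. Among the measured compounds shown here, no step between two measured compounds exists to calibrate this change. Compound 1 shows that a 3-hydroxyphenyl group alongside a 2-hydroxyphenyl group on this core also reaches only the limit > 50000 nM. The step is therefore expected to be a step that the limit leaves unreadable from compound 2 to compound 3, nothing beyond the usual scatter. Compound 3 is expected to give about 60000 nM, within a range from 20000 nM to 200000 nM, most likely reported as a limit once more.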

Compound 3, half-maximal inhibitory concentration: 9410 nM
Beside the measured number, compound 3's estimate is 6.4-fold (0.80 log units) above it; measured number below the stated range.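

In this assay, moving the hydroxyl group from 2-hydroxyphenyl to 3-hydroxyphenyl next to the ring nitrogen gives an at least 5.3-fold lower number from compound 2 to compound 3 (0.72 log units; beyond the scatter), so this position responds to where the hydroxyl group sits even though no atoms are gained or lost. Trifluoromethoxy in place of trifluoromethyl gives an at least 5.3-fold lower number from compound 1 to compound 3 (0.72 log units; beyond the scatter), so among these three compounds, the 3-hydroxyphenyl group yields a real number only when trifluoromethoxy is also present, and trifluoromethoxy yields one only with 3-hydroxyphenyl. Among the compounds shown here, compound 3 is the only compound here with a number, so both steps are minimum sizes and their full sizes cannot be read, with compound 1 and compound 2 each resting on a limit: the limit of > 50000 nM in this assay, at which 2 of the 3 values shown sit.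

The compounds shown leave open whether a 4-hydroxyphenyl group at this position would do better or worse, and whether the hydroxyl group itself is needed, as a methoxy group or an amine in its place would show. They also leave open what the same move would do to the remaining 2-hydroxyphenyl group, and why either change has the effect it has.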